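The source may report more compounds than this note shows. Statements on the series, on what has been measured and on what is new or still open speak of the compounds shown alone.

Measured compounds:
Compound 1, `Cc1ccsc1C(=O)OC(CCN(C)C)c1ccc(Cl)cc1`: in an assay on NIH3T3 cells with Urotensin-2 receptor (Homo sapiens) as the target (a higher number here means that more compound is needed for the effect, a lower number that less compound is needed), compound 1 gives 2510 nM.
Compound 2, `CCc1ccccc1C(=O)OC(CCN(C)C)c1ccc(Cl)cc1`: in this assay compound 2 gives 1290 nM.

The two compounds share the same core and differ only in the group attached to the carbonyl carbon. For the measured compounds named here, compound 2 has the lower of the two numbers, but the single measured step, a 1.9-fold lower number from compound 1 to compound 2 (0.29 log units; within the scatter), stays within the scatter, so the two values cannot be told apart with confidence.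

Compound 3, `Cc1cccc(C(=O)OC(CCN(C)C)c2ccc(Cl)cc2)c1C`, has not yet been measured. It differs from compound 2 by 2,3-dimethylphenyl in place of 2-ethylphenyl on a carbonyl carbon; the two have the same atoms, joined differently. Going by the values given here, the only measured step that bears on this change is the one from compound 1 to compound 2, where a far larger swap of the group on the carbonyl carbon moved the number by less than the scatter. A rearrangement of the same atoms within the same kind of ring is therefore expected to produce no step beyond the scatter in this assay. Compound 3 is estimated to give about 1300 nM, with a range from 500 nM to 3500 nM. The step this estimate implies is a 1.0-fold higher number from compound 2 to compound 3 (0.00 log units; within the scatter), an expectation rather than a measurement.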

Compound 3, half-maximal effective concentration: 1150 nM
Compound 3: middle estimate off by 1.1-fold (0.05 log units), on the high side; measured number inside the range.
By their numbers in this assay, from the lowest: compounds 3, 2 and 1 (each within the scatter of the next, the first and the last beyond it).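

On the carbonyl carbon, rearranging the same carbon atoms from 2-ethylphenyl into 2,3-dimethylphenyl gives a 1.1-fold lower number from compound 2 to compound 3 (0.05 log units; within the scatter) in this assay, so this first comparison of two carbon-only six-membered rings shows no difference that can be read. For the compounds shown here, changing the ring itself now gives a readable result for the first time: 2,3-dimethylphenyl in place of 3-methylthiophen-2-yl gives a 2.2-fold lower number from compound 1 to compound 3 (0.34 log units; beyond the scatter), a modest step. This does not establish a general preference for the six-membered ring over the thiophene, since compound 2 also carries such a ring and its step from compound 1 stayed within the scatter, so the separation holds only for this one pair.

All the groups at this position carry only small hydrocarbon substituents, which leaves open how the number would respond to a methoxy group, a chlorine atom, an amine or a carboxylic acid on the ring, or to a longer chain in place of the ethyl group. The data offer no measurement that explains even the modest step seen here.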